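A few compounds are considered here, and "the series" means these few. Any claim that something is new, unique, unknown or untested is made for them only; others in the source may bear on it.

Compound 3 `CC(C(=O)NCc1ccc(C(F)(F)F)nc1SCCC(=O)N1CCCC1)c1ccc(NS(C)(=O)=O)c(F)c1` gives 85 nM in an assay on CHO-K1 cells for antagonist activity at transient receptor potential cation channel subfamily V member 1 (Homo sapiens), read by FLIPR (a higher number here means a weaker inhibitor, a lower number a stronger inhibitor), the highest number among the three measured compounds; compound 1 `CC(C)CCSc1nc(C(F)(F)F)ccc1CNC(=O)C(C)c1ccc(NS(C)(=O)=O)c(F)c1` gives 0.7 nM and compound 2 `CC(C(=O)NCc1ccc(C(F)(F)F)nc1SCCCN1CCCCC1)c1ccc(NS(C)(=O)=O)c(F)c1` gives 3 nM. Compound 4 `Cc1ccc(CSc2nc(C(F)(F)F)ccc2CNC(=O)C(C)c2ccc(NS(C)(=O)=O)c(F)c2)cc1` differs from compound 3 by 4-methylphenyl in place of ((pyrrolidin-1-yl)carbonyl)methyl on a saturated chain carbon bound to a sulfur. The measured steps that bear on this change are a 4.3-fold higher number from compound 1 to compound 2 (0.63 log units; beyond the scatter), which is modest, and the large losses a 120-fold higher number from compound 1 to compound 3 (2.08 log units; beyond the scatter) and a 28-fold higher number from compound 2 to compound 3 (1.45 log units; beyond the scatter), both ending at the (pyrrolidin-1-yl)carbonyl that compound 4 no longer carries. A large fall in this assay is therefore expected for compound 4, roughly undoing the loss recorded in a 120-fold higher number from compound 1 to compound 3 (2.08 log units; beyond the scatter). The expected step is a 57-fold lower number from compound 3 to compound 4 (1.75 log units; beyond the scatter). Compound 4 is estimated at 1.5 nM, within a range from 0.4 nM to 6 nM.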

Compound 4, inhibition constant: 3.2 nM
Compound 4: middle estimate off by 2.1-fold (0.33 log units), on the low side; the measured number falls inside the stated range.
By their numbers in this assay, from the lowest: compound 1; then compounds 2 and 4 (each within the scatter of the next); then compound 3.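

In (this assay), an aromatic ring on the saturated chain carbon bound to a sulfur is tolerated: replacing the ((pyrrolidin-1-yl)carbonyl)methyl with 4-methylphenyl recovers most of the lost activity (a 27-fold lower number from compound 3 to compound 4 (1.42 log units; beyond the scatter)). Compound 4 cannot be told apart from the 2-(piperidin-1-yl)ethyl compound (a 1.1-fold higher number from compound 2 to compound 4 (0.03 log units; within the scatter)), but it does not match the isobutyl compound (a 4.6-fold higher number from compound 1 to compound 4 (0.66 log units; beyond the scatter)). Nothing given here accounts for these differences. From the compounds shown here alone, it remains open whether the 4-methyl contributes, as a plain phenyl or a 4-chlorophenyl would show. A pyridine ring in the same place is also untested among these compounds.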